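Cytotoxicity limit from compound 2 to compound 3

The compounds below may be only part of what the source reports. "The series", "measured", "known", "first", "only" and "open" are said of these compounds alone.

Compound 1 `CCC(CC)O[C@@H]1C=C(C(=O)O)C[C@H](NCc2ccc(OC(C)C)cc2)[C@H]1NC(C)=O` gives > 200000 nM as a limit
Compound 2 `CCC(CC)O[C@@H]1C=C(C(=O)O)C[C@H](NCc2ccc(Sc3cccs3)cc2)[C@H]1NC(C)=O` gives > 200000 nM as a limit

Compound 2 reads > 200000 nM in an ADME assay on cells (Fibroblast, Gallus gallus) for cytotoxicity, read by CCK-8 assay, with a stated time of 48 h (on this read-out lower numbers stand for higher toxicity in this test and higher numbers for lower toxicity in this test), and this is a limit of the assay, not a number. The next compound is compound 3 `CCC(CC)O[C@@H]1C=C(C(=O)O)C[C@H](NCc2ccc(-c3ccc4sccc4c3)cc2)[C@H]1NC(C)=O` and its change from compound 2 is 1-benzothiophen-5-yl in place of (thiophen-2-yl)sulfanyl on an aromatic carbon on the same core. Among the measured compounds shown here, the one measured step bearing on this change is a step that the two limits leave unreadable from compound 1 to compound 2 and it yields no size to carry over. What remains is the limit of > 200000 nM in this assay, at which 2 of the 2 values shown sit, and on that ground compound 3 is expected to sit at or close to the same limit. The expected step is a number no higher from compound 2 to compound 3 (the limit leaves the size open) and the measurements support no direction for it. The estimated value for compound 3 is 200000 nM within an expected range of 100000 nM to 400000 nM and this assay may well again report only a limit.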

Compound 3, half-maximal cytotoxic concentration: > 200000 nM
Compound 3 gave a limit, no number; the forecaster's own chance of this, stated with the estimate: 75%; the middle value lies on the limit itself.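

No new step can be read: the steps from compound 1 to compound 3 and from compound 2 to compound 3 both join limits of the assay, not numbers: the limit of > 200000 nM in this assay, at which 3 of the 3 values shown sit.

The compounds shown leave open what half-maximal cytotoxic concentration each actually has, and whether exchanging the group at this place changes it.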